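The source may report more compounds than this note shows. Statements on the series, on what has been measured and on what is new or still open speak of the compounds shown alone.

In a functional assay on HL-60 cells (Homo sapiens) for antiproliferative activity, with a stated time of 24 h (a higher number here means a weaker inhibitor, a lower number a stronger inhibitor), compound 2 `NC(=O)c1c(NC(=O)c2ccccc2Cl)sc2c1CCN(C(=S)Nc1cccc3ccccc13)C2` gives 13400 nM. Compound 1 `Cc1ccc(C(=O)Nc2sc3c(c2C(N)=O)CCN(Cc2c(Cl)cccc2Cl)C3)cc1` gives 10000 nM in this assay, and the two values lie within the scatter of each other, so neither compound can be set above the other. Compound 3 `COc1ccc(NC(=S)N2CCc3c(sc(NC(=O)c4ccccc4Cl)c3C(N)=O)C2)cc1` carries 4-methoxyphenyl in place of naphthalen-1-yl on an amide-type nitrogen. Going by the values given here, no pair of measured compounds shows a change of this kind, so the measured values give no guide to its size. A step of no size beyond the scatter, a 1.1-fold lower number from compound 2 to compound 3 (0.05 log units; within the scatter), is expected in this assay. Compound 3 is therefore estimated at 12000 nM, with a range from 4000 nM to 40000 nM.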

Compound 3, half-maximal inhibitory concentration: 15700 nM
Beside the measured number, compound 3's estimate is 1.3-fold (0.12 log units) below it, and the stated range covers the measured number.
By their numbers in this assay, from the lowest: compounds 1, 2 and 3 (each within the scatter of the next).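

In this assay the exchange of naphthalen-1-yl for 4-methoxyphenyl on the amide-type nitrogen gives a 1.2-fold higher number from compound 2 to compound 3 (0.07 log units; within the scatter) and so leaves compound 2 and compound 3 indistinguishable. At this position, then, a group with one six-membered aromatic ring and one hydrogen-bond acceptor reads the same as one with two such rings and no acceptor. No measurement in hand explains this result. As far as these compounds go, it remains open whether an amine, a carboxylic acid or a longer chain on this nitrogen would give a step beyond the scatter.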